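Swapping 1,3-benzothiazol-2-yl for 1H-benzimidazol-2-yl: a cytotoxicity estimate

The source may report more compounds than this note shows. Statements on the series, on what has been measured and on what is new or still open speak of the compounds shown alone.

Compound 1 `O=C(Nc1cccc(-c2nc3ccccc3s2)c1)c1cc([N+](=O)[O-])ccc1Cl` was examined in an ADME assay on BJ cells (Homo sapiens) for cytotoxicity, with a stated time of 72 h; a lower number here means that less compound is needed, a higher number that more compound is needed for the effect. There compound 1 stands only at a limit, not at a number, giving > 27000 nM. Two close relatives were measured alongside it. Compound 2 `O=C(Nc1ccc(F)c(-c2nc3ccccc3s2)c1)c1cc([N+](=O)[O-])ccc1Cl` carries fluoro in place of hydrogen on an aromatic carbon. In this assay compound 2 likewise reaches only a limit, > 25000 nM. Compound 3 `O=C(Nc1cc(-c2nc3ccccc3s2)ccc1F)c1cc([N+](=O)[O-])ccc1Cl` carries fluoro in place of hydrogen on a different aromatic carbon. Compound 3 also gives only a limit, > 25000 nM. The steps a step that the two limits leave unreadable from compound 1 to compound 2 and a step that the two limits leave unreadable from compound 1 to compound 3 therefore cannot be sized, because the limit of > 25000 nM in this assay, at which 2 of the 3 values shown sit, and the limit of > 27000 nM in this assay, at which 1 of the 3 values shown sits, hold every value in the set.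

Compound 4 `O=C(Nc1cccc(-c2nc3ccccc3[nH]2)c1)c1cc([N+](=O)[O-])ccc1Cl` differs from compound 1 by 1H-benzimidazol-2-yl in place of 1,3-benzothiazol-2-yl on an aromatic carbon. Neither measured step concerns this exchange, and both are unreadable, so they offer no direction or size to carry over. The author expects the step that the limit leaves unreadable from compound 1 to compound 4 to stay within the scatter, with the limit again likely. For compound 4 the estimate in this assay is 30000 nM, ranging from 10000 nM to 100000 nM.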

Compound 4, half-maximal effective concentration: > 27000 nM
Compound 4: a limit, no number; the forecaster's own chance of this, stated with the estimate: 75%; the middle value is on the limit's open side.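

In this assay compound 4 gives only a limit, > 27000 nM. Within the data shown here, compound 1 also stands at a limit, so no step from compound 1 to compound 4 can be read. The compounds shown leave open whether 1H-benzimidazol-2-yl in place of 1,3-benzothiazol-2-yl changes the half-maximal effective concentration at all.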